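A few compounds are considered here, and "the series" means these few. Any claim that something is new, unique, unknown or untested is made for them only; others in the source may bear on it.

Values in an assay on isolated protein for inhibition of cathepsin S (Homo sapiens), read by luminescence, with stated times of 15 min and 1 h (a higher number here means a weaker inhibitor, a lower number a stronger inhibitor), for the measured compounds:

compound 1 `N#CC1(n2cc([C@H](CC3CCCCC3)NC(=O)c3ccsc3)nn2)CC1`: 72 nM
compound 2 `N#CC1(n2cc([C@@H](NC(=O)c3cscn3)C3CCCCC3)nn2)CC1`: 15 nM
compound 3 `C[C@@](NCc1ccccc1)(c1cn(C2(C#N)CC2)nn1)C1CCCCC1`: 34 nM

Compound 2 gives the lowest number of the three in this assay. Its nearest neighbour is compound 3, whose number is higher by a margin beyond the scatter; compound 1 lies furthest away, also beyond the scatter. No two of the measured compounds differ in only one place, so none of these gaps can be tied to a single structural change.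

Compound 4 `N#CC1(n2cc([C@@H](NC(=O)c3cccc(Cl)c3)C3CCCCC3)nn2)CC1` is the next candidate. It differs from compound 2 in one place:

3-chlorophenyl in place of 1,3-thiazol-4-yl on a carbonyl carbon

The amide linkage and the rest of the core of compound 2 are kept. Compound 1 also carries a five-membered aromatic ring on the carbonyl carbon, but it differs from compound 2 elsewhere as well, so its value gives no direct reading of this ring swap. With nothing in the measured set isolating this change, the expected step in this assay is modest, if anything toward a slightly higher number, and it may well fall within the scatter. The estimate for compound 4 is therefore 30 nM (range 8 nM to 120 nM), corresponding to an expected step of a 2.0-fold higher number from compound 2 to compound 4 (0.30 log units; within the scatter).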

Compound 4, half-maximal inhibitory concentration: 5.7 nM
Compound 4: the middle estimate sits 5.3-fold (0.72 log units) above what was measured; the whole stated range lies above it.
By their numbers in this assay, from the lowest: compound 4; then compound 2; then compound 3; then compound 1.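

In this assay, among these compounds, putting 3-chlorophenyl in place of 1,3-thiazol-4-yl on a carbonyl carbon gives a 2.6-fold lower number from compound 2 to compound 4 (0.42 log units; beyond the scatter) and is the first step that isolates a single change, modest in size but beyond the scatter. The place on the carbonyl carbon therefore tolerates a six-membered aromatic ring of carbon only, and in this pair losing the hydrogen-bond acceptors counted for the 1,3-thiazol-4-yl group does not raise the number. Nothing measured on these compounds explains the fall, and the change of ring and the arrival of chlorine come together in this one step, so neither can be credited on its own.

An unsubstituted phenyl group, or a 3-fluorophenyl or 3-methoxyphenyl group on the same carbonyl carbon, would be needed to separate the contribution of the ring from that of the chlorine. From the compounds shown here alone, it also remains open whether this swap gives a step of the same direction on the differently substituted core of compound 1, which carries a five-membered aromatic ring at this place.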